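Adding a Second Trifluoromethyl to a Sulfone Anilide

A few compounds are considered here, and "the series" means these few. Any claim that something is new, unique, unknown or untested is made for them only; others in the source may bear on it.

Measured compounds:
compound 1, `CC(O)(COc1ccc(C#N)cc1)C(=O)Nc1cccc(S(F)(F)(F)(F)F)c1`, 26600 nM
compound 2, `CC(O)(COc1ccc(C#N)cc1C(F)(F)F)C(=O)Nc1cccc(S(F)(F)(F)(F)F)c1`, 30600 nM
compound 3, `CC(O)(CS(=O)(=O)c1cccc(C(F)(F)F)c1)C(=O)Nc1ccc(S(F)(F)(F)(F)F)cc1`, 32000 nM

In a functional assay on VCaP cells (Homo sapiens) for antiproliferative activity, read by propidium iodide staining, with a stated time of 96 h (on this read-out lower numbers stand for stronger inhibition and higher numbers for weaker inhibition), compound 1 gives 26600 nM. Compound 2 differs from it by trifluoromethyl in place of hydrogen on an aromatic carbon, and the step is a 1.2-fold higher number from compound 1 to compound 2 (0.06 log units; within the scatter). Compound 3 gives 32000 nM; how its core differs from that of compound 1 is not broken down here. Compound 4, `CC(O)(CS(=O)(=O)c1cc(C(F)(F)F)cc(C(F)(F)F)c1)C(=O)Nc1ccc(S(F)(F)(F)(F)F)cc1`, differs from compound 3 by trifluoromethyl in place of hydrogen on an aromatic carbon. This is the same kind of change as from compound 1 to compound 2, not the same: there the entering group sat ortho to a large group and meta to a cyano group, here it sits meta to a large group and meta to a trifluoromethyl group. Because a 1.2-fold higher number from compound 1 to compound 2 (0.06 log units; within the scatter) stayed within the scatter, compound 4 is expected to move by a 1.1-fold higher number from compound 3 to compound 4 (0.05 log units; within the scatter). Compound 4 is estimated at 36000 nM, between 16000 nM and 80000 nM.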

Compound 4, half-maximal inhibitory concentration: 15800 nM
Compound 4: middle estimate off by 2.3-fold (0.36 log units), on the high side; measured number below the stated range.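

In this assay, trifluoromethyl in place of hydrogen on an aromatic carbon gives a 2.0-fold lower number from compound 3 to compound 4 (0.31 log units; beyond the scatter), a modest step. The earlier step on the core of compound 1 stayed within the scatter and this one lies beyond it, yet the two cannot be told apart: the same change on two cores in this assay, a 1.2-fold higher number (0.06 log units; within the scatter) from compound 1 to compound 2 and a 2.0-fold lower number (0.31 log units; beyond the scatter) from compound 3 to compound 4, 2.3-fold (0.37 log units) apart, within the scatter of two such steps. The pair therefore does not show that the core alters the outcome of this change, and it does not show that the change carries over unchanged either.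

The compounds shown leave open whether a chlorine, a methoxy or an amine in the same place would track with trifluoromethyl. They also leave open what a carboxylic acid in place of the nitrile would do.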